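Amino for fluoro on the aromatic ring of compound 2

A few compounds are considered here, and "the series" means these few. Any claim that something is new, unique, unknown or untested is made for them only; others in the source may bear on it.

The series shares one core carrying a urea and a substituted cycloalkyl-linked aryl group. Compound 1 `CC(C)c1cccc(C(C)C)c1NC(=O)NCC1(c2ccc(CC(C)(C)C)cc2)CCCC1` gives 159 nM in an assay on microsomes for inhibition of acyl-CoA:cholesterol acyltransferase (Oryctolagus cuniculus); on this read-out higher numbers stand for weaker inhibition and lower numbers for stronger inhibition. Compound 2 `CC(C)c1cccc(C(C)C)c1NC(=O)NCC1(c2ccc(F)cc2)CCCC1` gives 23 nM in this assay, and compound 3 `CC(C)c1cccc(C(C)C)c1NC(=O)NCC1(c2ccccc2C(F)(F)F)CCCC1` gives 18 nM there. Compound 2 thus stands second highest of the three numbers; its nearest neighbour is compound 3, within the scatter (a 1.3-fold lower number from compound 2 to compound 3 (0.11 log units; within the scatter)), its furthest compound 1, beyond it (a 6.9-fold lower number from compound 1 to compound 2 (0.84 log units; beyond the scatter)).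

Compound 4 `CC(C)c1cccc(C(C)C)c1NC(=O)NCC1(c2ccc(N)cc2)CCCC1` differs from compound 2 by amino in place of fluoro on an aromatic carbon. Among the measured compounds shown here, the only measured step at this position is the one from compound 1 to compound 2 (a 6.9-fold lower number from compound 1 to compound 2 (0.84 log units; beyond the scatter)), where fluoro replaced neopentyl; no measured step introduces an amino group anywhere, so direction cannot be read from the data. The expectation is a small step from compound 2 to compound 4, a 2.0-fold higher number from compound 2 to compound 4 (0.29 log units; within the scatter), likely within the scatter. Compound 4 is therefore estimated at 45 nM in this assay, with a range of 15 nM to 130 nM.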

Compound 4, half-maximal inhibitory concentration: 29 nM
Compound 4: middle estimate off by 1.6-fold (0.19 log units), on the high side, within the range that was stated.
By their numbers in this assay, from the lowest: compounds 3, 2 and 4 (each within the scatter of the next); then compound 1.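

In this assay, amino in place of fluoro, which brings a hydrogen-bond donor and a hydrogen-bond acceptor onto this aromatic carbon, gives a step within the scatter (a 1.3-fold higher number from compound 2 to compound 4 (0.10 log units; within the scatter)), so the two groups cannot be told apart here. The change of aryl group is also within the scatter (a 1.6-fold higher number from compound 3 to compound 4 (0.21 log units; within the scatter)), whereas the change from neopentyl remains beyond it (a 5.5-fold lower number from compound 1 to compound 4 (0.74 log units; beyond the scatter)), so at this position only neopentyl stands apart from fluoro and amino. Nothing available bears on why fluoro and amino read alike.

Open, from the compounds shown here alone, is whether a carboxylic acid or a dimethylamino group on this carbon would also stay within the scatter of fluoro and amino. Also open, going by these compounds, is whether a methyl or an ethyl group would read with those two or with neopentyl.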